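The source may report more compounds than this note shows. Statements on the series, on what has been measured and on what is new or still open speak of the compounds shown alone.

Compound 1 `COc1ccc(Oc2ccc3nc(/C=C/C(=O)NO)ccc3c2)cc1` gives 3200 nM
Compound 2 `CC(C)c1ccc(Oc2ccc3nc(/C=C/C(=O)NO)ccc3c2)cc1` gives 3280 nM

Both values come from a functional assay on A549 cells (Homo sapiens) for antiproliferative activity, read by sulforhodamine B assay, with a stated time of 48 h; on this read-out higher numbers stand for weaker inhibition of growth and lower numbers for stronger inhibition of growth. In this assay compound 2, at 3280 nM, cannot be told apart from compound 1, so the two sit level. Compound 3 `O=C(/C=C/c1ccc2cc(Oc3ccc([N+](=O)[O-])cc3)ccc2n1)NO` has nitro in place of isopropyl on an aromatic carbon, para to a large group (nitro in place of isopropyl on an aromatic carbon). Going by the values given here, only one measured step bears on this change: a 1.0-fold higher number from compound 1 to compound 2 (0.01 log units; within the scatter), with isopropyl in place of methoxy on an aromatic carbon. That swap left the number within the scatter, so no shift beyond the scatter is expected here. Among the compounds with values here, still, no compound with nitro has been measured, and a single step is thin evidence, so the range is kept wide. The expected change is a 1.1-fold lower number from compound 2 to compound 3 (0.04 log units; within the scatter). For compound 3 the estimated value is 3000 nM, with an expected range of 1200 nM to 7500 nM.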

Compound 3, concentration for 50% growth inhibition: 1630 nM
Estimate against measurement, compound 3: 1.8-fold (0.26 log units) above, within the range that was stated.
By their numbers in this assay, from the lowest: compounds 3, 1 and 2 (each within the scatter of the next).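

In this assay, a third group on this aromatic carbon, para to a large group, again leaves the number within the scatter: a 2.0-fold lower number from compound 2 to compound 3 (0.30 log units; within the scatter), and a 2.0-fold lower number from compound 1 to compound 3 (0.29 log units; within the scatter). Nitro brings 2 hydrogen-bond acceptors where isopropyl brings 0, yet compounds 1, 2 and 3 still cannot be told apart, so this change of group gives no measurable shift in growth inhibition among these three compounds. No measurement is available that would explain this result.

As far as these compounds go, whether an amine, a carboxylic acid or a longer chain on this carbon would move the number beyond the scatter remains open. Also open, from the compounds shown here alone, is whether these three groups would still sit level on another carbon of the same ring.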